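Exchanging the Capping Group on the Amine Nitrogen

The source may hold more compounds than are shown below. What is called first, only, known or untested is meant among the compounds shown, and "the series" means these compounds.

Measured compounds, with their half-maximal inhibitory concentrations in an assay on THP-1 cells for displacement of a labelled ligand from C-C chemokine receptor type 1 (Homo sapiens); a lower number here means a stronger inhibitor, a higher number a weaker inhibitor:
compound 1, `CC(C)C(=O)NC(C(=O)N1CCC(c2ccc(Cl)cc2)CC1)C(C)C`: 388 nM
compound 2, `CC(C)C(NS(=O)(=O)Cc1ccccc1)C(=O)N1CCC(c2ccc(Cl)cc2)CC1`: 303 nM
compound 3, `CC[C@@H](NC(=O)CCc1ccccc1)C(=O)N1CCC(c2ccc(Cl)cc2)CC1`: 85 nM

Among these three numbers compound 2 stands second highest. Its nearest neighbour is compound 1, and the step of a 1.3-fold lower number from compound 1 to compound 2 (0.11 log units; within the scatter) lies within the scatter. Compound 3 is furthest away, with the lowest number of the three.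

Compound 4, `Cc1ccccc1C(=O)NC(C(=O)N1CCC(c2ccc(Cl)cc2)CC1)C(C)C`, differs from compound 2 in one place: (2-methylphenyl)carbonyl in place of benzylsulfonyl on an amine nitrogen. Among the compounds with values here, the only measured step that bears on it is the one from compound 1 to compound 2, which also swapped the group on this nitrogen and stayed within the scatter. Compound 4 is therefore expected to show a step of a 1.2-fold lower number from compound 2 to compound 4 (0.07 log units; within the scatter), with no change beyond the scatter. For compound 4 the estimate in this assay is 260 nM, expected between 80 nM and 850 nM.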

Compound 4, half-maximal inhibitory concentration: 36 nM
Compound 4: the middle estimate sits 7.2-fold (0.86 log units) above what was measured; measured number below the stated range.
By their numbers in this assay, from the lowest: compound 4; then compound 3; then compounds 2 and 1 (each within the scatter of the next).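

In this assay, the capping group on this amine nitrogen proves able to shift the number well beyond the scatter, which a 1.3-fold lower number from compound 1 to compound 2 (0.11 log units; within the scatter) did not show: (2-methylphenyl)carbonyl in place of benzylsulfonyl gives an 8.4-fold lower number from compound 2 to compound 4 (0.93 log units; beyond the scatter). The same group in place of the isopropylcarbonyl group, a change of 2-methylphenyl for isopropyl on a carbonyl carbon, gives an 11-fold lower number from compound 1 to compound 4 (1.03 log units; beyond the scatter). Nothing available accounts for this difference.

The compounds shown leave open how a plain phenylcarbonyl group on this nitrogen would compare with (2-methylphenyl)carbonyl, and so what the methyl group on the ring contributes.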